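The source may report more compounds than this note shows. Statements on the series, on what has been measured and on what is new or still open speak of the compounds shown alone.

Compound 1, with the structure `CCCCc1cc(OC)c2ccccc2c1OC(C)=O`, gives 440 nM in a functional assay for inhibition, with Rattus norvegicus as the target; on this read-out lower numbers stand for stronger inhibition and higher numbers for weaker inhibition. Compound 2, with the structure `CCCCc1cc(OC)c2ccccc2c1O`, gives 1470 nM in this assay. The two differ in one place, (hydrogen in place of acetyl on an oxygen on an aromatic ring), and the step recorded for that change is a 3.3-fold higher number from compound 1 to compound 2 (0.52 log units; beyond the scatter).

Compound 3, with the structure `CCCCc1cc(OC)c2occc2c1OC(C)=O`, gives 110 nM in this assay, the lowest of the three numbers recorded. Compound 3 and compound 1 differ in their cores, and the difference between the two cores is not broken down here.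

Compound 4, with the structure `CCCCc1cc(OC)c2occc2c1O`, has not yet been measured. It stands to compound 3 as compound 2 stands to compound 1: the change is hydrogen in place of acetyl on an oxygen on an aromatic ring, and the place at which it is made is described in the same words for both pairs, so it is the same change, seen twice among these compounds.

Among the compounds with values here, the only guide for compound 4 is that one earlier step. For compound 4 the step is therefore expected to be a 3.3-fold higher number from compound 3 to compound 4 (0.51 log units; beyond the scatter), close in size to the step from compound 1 to compound 2, because compound 3 starts from 110 nM and the same change earlier gave a 3.3-fold higher number from compound 1 to compound 2 (0.52 log units; beyond the scatter). On that basis compound 4 is estimated to give about 360 nM in this assay, with a plausible range from 150 nM to 900 nM, the range being wide since it rests on a single earlier pair.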

Compound 4, half-maximal inhibitory concentration: 11900 nM
The estimate for compound 4 lay 33-fold (1.52 log units) below the measured number; the measured number lies above the stated range.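

In this assay, going from acetoxy to hydroxy on the core of compound 3 gives a 110-fold higher number from compound 3 to compound 4 (2.03 log units; beyond the scatter), a step in the same direction as on the core of compound 1 but not of the same size: the same change on two cores in this assay, a 3.3-fold higher number (0.52 log units; beyond the scatter) from compound 1 to compound 2 and a 110-fold higher number (2.03 log units; beyond the scatter) from compound 3 to compound 4, 32-fold (1.51 log units) apart, beyond the scatter of two such steps. Across these two cores, then, the direction of the change carried over and its size did not, so the step read on one core was no measure of the step on the other. The two pairs do not show why the size differs, which feature of the two cores is responsible, or how the change would behave on any third core.

The compounds shown leave open whether a methyl ether or a longer acyl chain on that same oxygen would also give steps that differ so widely between the two cores. They also leave open whether the gap between the two steps would persist with a longer chain in place of the alkyl chain shared by all four compounds.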